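Aryl exchange on a saturated ring carbon

The compounds below may be only part of what the source reports. "The series", "measured", "known", "first", "only" and "open" are said of these compounds alone.

Values measured so far in a physicochemical assay for lipophilicity (on this read-out higher numbers stand for higher lipophilicity and lower numbers for lower lipophilicity), are as follows.
Compound 1 `C[C@H]1CC[C@@H]2[C@@H](OC(=O)[C@]23CC(c2ccc(N(C)C)cc2)=NO3)[C@]2(C)C(=O)C=C[C@@]12O` gives 1.51
Compound 2 `C[C@H]1CC[C@@H]2[C@@H](OC(=O)[C@]23CC(c2ccc(F)cc2)=NO3)[C@]2(C)C(=O)C=C[C@@]12O` gives 1.58
Compound 3 `Cc1ccc(C2C[C@@]3(ON2c2ccccc2)C(=O)O[C@@H]2[C@H]3CC[C@H](C)[C@]3(O)C=CC(=O)[C@@]23C)cc1` gives 3.64

Compound 3 stands highest of the three, beyond the scatter from both compound 1 and compound 2. Those two gaps offer little guidance here, as neither compound differs from compound 3 in only one place.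

Compound 4 `C[C@H]1CC[C@@H]2[C@@H](OC(=O)[C@]23CC(c2ccccc2Cl)N(c2ccccc2)O3)[C@]2(C)C(=O)C=C[C@@]12O` is still unmeasured. It departs from compound 3 in a single place (2-chlorophenyl in place of 4-methylphenyl on a saturated ring carbon), with 2-chlorophenyl in place of 4-methylphenyl on a saturated ring carbon. The phenyl group on the ring atom next to that carbon stays the same.

Among the compounds with values here, one measured step bears on this change, and only indirectly: a number 0.07 log units higher from compound 1 to compound 2 (within the scatter), with fluoro in place of dimethylamino on an aromatic carbon. That step is small and lies within the scatter, but it comes from a different place on a different core. Within the data shown here, no measured step exchanges one aryl group for another at this saturated ring carbon.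

On that limited evidence, no step beyond the scatter is expected in this assay, and neither direction is favoured. The expected step is a number 0.01 log units higher from compound 3 to compound 4 (within the scatter). Compound 4 is estimated at 3.65, with an expected range from 3.25 to 4.05.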

Compound 4, partition coefficient: 3.87
Estimate against measurement, compound 4: 0.22 log units below; measured number inside the range.
By their numbers in this assay, from the lowest: compounds 1 and 2 (each within the scatter of the next); then compounds 3 and 4 (each within the scatter of the next).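

In this assay, within the data shown here, this is the first measured exchange of one aryl group for another on this saturated ring carbon, and it reads a number 0.23 log units higher from compound 3 to compound 4 (within the scatter). The pair therefore places compound 3 and compound 4 together at the upper end of the series, with 2-chlorophenyl and 4-methylphenyl not separated on this read-out while the ring atom that bears a phenyl group stays the same. Among these compounds, the step belongs to this place on this core, unlike the only earlier step, which lay on an aromatic carbon of a different core, and no measurement here bears on why the exchange gives a step of this size.

This single pair changes the substituent and its place on the aryl ring together, so 4-chlorophenyl or 2-methylphenyl at the same carbon would be needed to tell those two changes apart. It also leaves open whether the read-out would stay within the scatter with an aryl group carrying an amine or a carboxylic acid on this carbon, or with a longer saturated chain in place of the aryl group.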